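Third aryl amide on a baseline of two limits

The source may hold more compounds than are shown below. What is called first, only, known or untested is meant among the compounds shown, and "the series" means these compounds.

Compound 1, `O=C(CSc1nc(Nc2ccccc2)c2ccccc2n1)Nc1ccc(F)cc1`: in a functional assay on MGC-803 cells (Homo sapiens) for inhibition, read by MTT assay, with a stated time of 72 h (a higher number here means a weaker inhibitor, a lower number a stronger inhibitor), compound 1 gives > 50000 nM.
Compound 2, `O=C(CSc1nc(Nc2ccccc2)c2ccccc2n1)Nc1ccc([N+](=O)[O-])cc1`: in this assay compound 2 gives > 50000 nM.

Both of these values are limits of the assay rather than numbers. Going by the values given here, compound 2 therefore stands only at a limit, and the one measured step, a step that the two limits leave unreadable from compound 1 to compound 2, cannot be read in size or direction. The place where compound 2 stands is described by the limit of > 50000 nM in this assay, at which 2 of the 2 values shown sit.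

Compound 3, `O=C(CSc1nc(Nc2ccccc2)c2ccccc2n1)Nc1ccc(Cl)cc1Cl`, differs from compound 2 in one place: 2,4-dichlorophenyl in place of 4-nitrophenyl on an amide-type nitrogen. Among the compounds with values here, the only measured step that bears on this change is the one from compound 1 to compound 2, and since both ends of it sit at the same limit, it gives no readable size and no direction. There is thus no basis for expecting a step beyond the usual scatter in this assay in either direction; the most likely outcome is that compound 3 also stays at the limit.

Compound 3 is therefore estimated at 60000 nM in this assay, with a range from 15000 nM to 200000 nM. The expected step that the limit leaves unreadable from compound 2 to compound 3 is accordingly essentially flat.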

Compound 3, half-maximal inhibitory concentration: 12300 nM
Compound 3: the middle estimate sits 4.9-fold (0.69 log units) above what was measured; the whole stated range lies above it.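

The amide-type nitrogen now proves to be a place where the aryl group can move the result: in this assay, 2,4-dichlorophenyl in place of 4-nitrophenyl gives an at least 4.0-fold lower number from compound 2 to compound 3 (0.60 log units; beyond the scatter), and 2,4-dichlorophenyl in place of 4-fluorophenyl gives an at least 4.0-fold lower number from compound 1 to compound 3 (0.60 log units; beyond the scatter). Each of these steps starts from a limit of the assay and not from a number, so each gives only the smallest size the change can have, and the step that joins the two limits still cannot be read. Compound 3 is the only one of the three with a true number, which gives the series its first fixed point, while the other two values remain at the same limit: the limit of > 50000 nM in this assay, at which 2 of the 3 values shown sit.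

The compounds shown do not tell whether both chlorine atoms are needed or whether a single chlorine atom on the phenyl ring would give a similar number. Also open, going by these compounds, is how the number would respond to quite different groups at this place, such as an amine or a carboxylic acid on the ring, or a longer chain on the same nitrogen.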